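This account rests on a few compounds, and the source may have more. Where it says the series, first, only, none or still open, it means among the compounds named here.

Compound 1 `Cc1cccc(NC(=O)CSC(=S)N[C@H]2CCOC2=O)c1` was examined in a functional assay on EC9706 cells (Homo sapiens) for cytotoxicity, read by MTT assay, with a stated time of 72 h; a lower number here means a stronger inhibitor, a higher number a weaker inhibitor; in this assay compound 1 gives > 128000 nM, which is a limit of the assay and not a number. Compound 2 `O=C(CSC(=S)N[C@H]1CCOC1=O)Nc1ccccc1` in this assay gives > 128000 nM, again only a limit. The step that the two limits leave unreadable from compound 1 to compound 2 therefore has no readable size because the limit of > 128000 nM in this assay, at which 2 of the 2 values shown sit, holds both values. Compound 2 thus stands at the limit, with no numbered value of its own among the data shown.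

Compound 3 `O=C(CSC(=S)N[C@H]1CCOC1=O)Nc1cccc(C(F)(F)F)c1` differs from compound 2 by trifluoromethyl in place of hydrogen on an aromatic carbon. For the measured compounds named here, the only measured step that bears on this change, also an exchange on an aromatic carbon, is unreadable, so nothing in the data points to a step in this assay in either direction beyond the scatter. Compound 3 is therefore expected to give 200000 nM, with a range from 60000 nM to 600000 nM. The step from compound 2 is estimated as a step that the limit leaves unreadable from compound 2 to compound 3.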

Compound 3, half-maximal inhibitory concentration: 79700 nM
The estimate for compound 3 lay 2.5-fold (0.40 log units) above the measured number, and the stated range covers the measured number.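

With trifluoromethyl on the aromatic carbon, compound 3 gives 79700 nM in this assay, the first numbered value among the compounds shown, so a change at this place can bring the read-out within the measurable range. Against hydrogen the change reads as an at least 1.6-fold lower number from compound 2 to compound 3 (0.20 log units; that floor lies within the scatter), and against methyl it reads as an at least 1.6-fold lower number from compound 1 to compound 3 (0.20 log units; that floor lies within the scatter). Both steps are floors rather than sizes, and neither floor lies beyond the scatter, because compound 1 and compound 2 each remain at a limit: the limit of > 128000 nM in this assay, at which 2 of the 3 values shown sit.

The compounds shown leave open whether the numbered value is particular to trifluoromethyl, or whether a chlorine atom, a nitrile or a methoxy group at the same place would also give one. They also leave open how trifluoromethyl would read elsewhere on the ring.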